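Compound 3 to compound 4: propylsulfonyl exchanged

A few compounds are considered here, and "the series" means these few. Any claim that something is new, unique, unknown or untested is made for them only; others in the source may bear on it.

- compound 1 `Cc1cc(C)c(NC(=O)c2sccc2S(=O)(=O)Nc2onc(C)c2Cl)c(C)c1` gives 81600 nM
- compound 2 `Cc1cc(C)c(OC2CC2)c(C)c1NC(=O)c1sccc1S(=O)(=O)Nc1onc(C)c1Cl` gives 12300 nM
- compound 3 `CCCS(=O)(=O)c1cc(C)cc(C)c1NC(=O)c1sccc1S(=O)(=O)Nc1onc(C)c1Cl` gives 5450 nM

In an in vivo ADME assay on the whole organism (plasma) for pharmacokinetics, with Rattus norvegicus as the target, at a dose of 50 mg/kg by the oral route (on this read-out lower numbers stand for lower exposure and higher numbers for higher exposure at the dose given), compound 3 stands lowest of the three, beyond the scatter from both others. Compound 4 `Cc1cc(C)c(NC(=O)c2sccc2S(=O)(=O)Nc2onc(C)c2Cl)c(C(=O)C2CC2)c1` has cyclopropylcarbonyl in place of propylsulfonyl on an aromatic carbon on an aromatic carbon. Among the measured compounds shown here, no measured step covers this exchange directly. The large step of a 15-fold lower number from compound 1 to compound 3 (1.18 log units; beyond the scatter) came with propylsulfonyl in place of methyl, and the modest step of a 6.6-fold lower number from compound 1 to compound 2 (0.82 log units; beyond the scatter) came with cyclopropyloxy in place of hydrogen. Compound 2 also carries a cyclopropyl group and holds 12300 nM in this assay so a modest rise is expected. The expected step is a 2.6-fold higher number from compound 3 to compound 4 (0.41 log units; beyond the scatter) and stays short of the level of compound 1. Compound 4 is estimated at 14000 nM (range 4000 nM to 45000 nM).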

Compound 4, maximal plasma concentration: 108000 nM
Compound 4: middle estimate off by 7.7-fold (0.89 log units), on the low side, and the stated range ends below it.
By their numbers in this assay, from the lowest: compound 3; then compound 2; then compounds 1 and 4 (each within the scatter of the next).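

In this assay, a large group on this aromatic carbon does not by itself bring low exposure: cyclopropylcarbonyl in place of propylsulfonyl gives a 20-fold higher number from compound 3 to compound 4 (1.30 log units; beyond the scatter). Set against methyl, the same group gives a 1.3-fold higher number from compound 1 to compound 4 (0.12 log units; within the scatter), so the position accepts cyclopropylcarbonyl with exposure level with methyl. Nothing at hand bears on why the two large groups differ. Open, from the compounds shown here alone, is whether the low value of compound 3 follows the sulfonyl or the propyl chain, which methylsulfonyl or a propanoyl group would separate. Also open, going by these compounds, is how an amine or a carboxylic acid behaves at this position.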